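Swapping a piperidine for an aminophenyl on a tryptophan dioxygenase series

A few compounds are considered here, and "the series" means these few. Any claim that something is new, unique, unknown or untested is made for them only; others in the source may bear on it.

Measured so far:
- compound 1, `O=[N+]([O-])c1cccc(CNc2cc(C(F)(F)F)cc3[nH]ncc23)c1`: 60%
- compound 2, `FC(F)(F)c1cc(NC[C@H]2CCCCN2)c2cn[nH]c2c1`: 69%

In an assay for inhibition of Tryptophan 2,3-dioxygenase (Homo sapiens), with stated times of 10 min and 60 min, tested at 10 uM (on this read-out higher numbers stand for a stronger effect at the one concentration tested and lower numbers for a weaker effect), compound 2 gives 69%, and compound 1 gives 60%. These two numbers differ by less than the usual scatter of repeated measurements, so neither compound can be called the stronger one on this evidence; both simply block the enzyme to a similar degree at the single concentration tested.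

Compound 3, `Nc1cccc(CNc2cc(C(F)(F)F)cc3[nH]ncc23)c1`, has not been measured yet. Relative to compound 2, the change is 3-aminophenyl in place of piperidin-2-yl on a saturated chain carbon bound to a nitrogen on an aromatic ring, so a saturated ring carrying a basic nitrogen gives way to a flat aromatic ring with its own nitrogen as an amine, while the shared core and the trifluoromethyl group stay untouched.

Within the data shown here, no step between measured compounds is available to calibrate this kind of change, so the expectation rests on compound 1 and compound 2 showing similar inhibition with rather different groups at this position. On that basis the step in this assay is expected to be small, a number 11 percentage points lower from compound 2 to compound 3 (beyond the scatter), most likely staying within the scatter. Compound 3 is therefore estimated to give 58%, with a range from 35% to 80%.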

Compound 3, a percentage reported as inhibition, at one concentration (the size of the read-out at that concentration, not a potency): 68%
For compound 3 the middle estimate is 10 percentage points below the measured one; low and high end bracket the measured number.
By their numbers in this assay, from the lowest: compounds 1, 3 and 2 (each within the scatter of the next).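

In this assay, among these compounds, 3-aminophenyl in place of piperidin-2-yl on a saturated chain carbon bound to a nitrogen on an aromatic ring gives a number 1 percentage points lower from compound 2 to compound 3 (within the scatter), so exchanging a saturated ring for an aromatic one produces no step that can be told from the scatter. Amino in place of nitro on an aromatic carbon gives a number 8 percentage points higher from compound 1 to compound 3 (within the scatter), which is the first comparison with the aromatic ring held constant, and it too stays within the scatter, so all three groups at this place read alike at the one concentration tested. Nothing in hand bears on what lies behind these numbers.

An unsubstituted phenyl ring, a carboxylic acid on the aromatic ring or a longer chain in place of the saturated chain carbon would test whether this place stays as undemanding once the group departs further from these three. The numbers also come from one concentration and are not potencies, so a full concentration series could still separate compounds that look the same here.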